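The compounds below may be only part of what the source reports. "The series", "measured", "known", "first", "only" and "open" are said of these compounds alone.

Measured so far in a functional assay on the whole organism (strain Wistar) for inhibition, with Rattus norvegicus as the target, read by paw edema, with stated times of 60 min and 1 h, at a dose of 100 mg/kg by the oral route; on this read-out lower numbers stand for less inhibition and higher numbers for more inhibition at the one dose given (going by the name of the read-out):
Compound 1, `CCCCCCNC(=O)CC1CCc2cc(OC)c(OC)cc21`: 47.6%
Compound 2, `COc1cc2c(cc1OC)C(CC(=O)N1CCCCC1)CC2`: 18.8%
Compound 3, `COc1cc2c(cc1OC)C(CC(=O)N1CCOCC1)CC2`: 15.6%

Compound 3 stands lowest of the three numbers, though its gap to compound 2 lies within the scatter, as a number 3.2 percentage points lower from compound 2 to compound 3 (within the scatter) shows; only compound 1 stands clearly apart from it, as a number 32 percentage points lower from compound 1 to compound 3 (beyond the scatter) shows. Compound 4, `COc1cc2c(cc1OC)C(CC(=O)NCCO)CC2`, is the next compound to be measured in this assay. It differs from compound 3 in one place: (2-hydroxyethyl)amino in place of morpholin-4-yl on a carbonyl carbon. Among the compounds with values here, the steps that bear on this change are the two replacements of an open-chain amino group by a ring on the carbonyl carbon, a number 32 percentage points lower from compound 1 to compound 3 (beyond the scatter) and a number 28.8 percentage points lower from compound 1 to compound 2 (beyond the scatter), both of which brought the number down well beyond the scatter. Within the data shown here, compound 4 goes the other way, from a ring back to an open chain, so an increase is expected; yet (2-hydroxyethyl)amino is a shorter chain than hexylamino, and no measured compound shows what that difference does, so the rise is expected to fall short of the number given by compound 1. Compound 4 is therefore expected to rise by a number 16.4 percentage points higher from compound 3 to compound 4 (beyond the scatter), to about 32%, with a range from 15% to 50%.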

Compound 4, a percentage reported as inhibition, in the whole organism at one dose (the size of the read-out at that dose, not a potency): 0%
Beside the measured number, compound 4's estimate is 32 percentage points above it, outside the stated range (below it).
By their numbers in this assay, from the lowest: compound 4; then compounds 3 and 2 (each within the scatter of the next); then compound 1.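

In this assay, replacing either ring on the carbonyl carbon with (2-hydroxyethyl)amino gave a number 15.6 percentage points lower from compound 3 to compound 4 (beyond the scatter) and a number 18.8 percentage points lower from compound 2 to compound 4 (beyond the scatter), so an open chain at this place does not by itself give a higher number than a ring, as compound 1 alone had suggested. The two open-chain amides also stand far apart: hydroxy in place of butyl on a saturated chain carbon, two bonds along the chain from an amide-type nitrogen, gave a number 47.6 percentage points lower from compound 1 to compound 4 (beyond the scatter), which makes this the largest of the new steps and shows that the make-up of the chain matters as much as whether a ring is present. Nothing available explains why the number falls with this change.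

Compound 4 differs from compound 1 in both the length of the chain and its hydroxy end, so the compounds shown leave open which of the two accounts for the loss. Ethylamino would test the shorter chain without the hydroxy, and 6-hydroxyhexylamino would test the hydroxy on the longer chain.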